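The source may hold more compounds than are shown below. What is called first, only, known or untested is meant among the compounds shown, and "the series" means these compounds.

Compound 1 `Cc1cc(C(=O)NCN2CCC(c3cccc[n+]3[O-])CC2)ccc1F`: 50 nM. Compound 2 `Cc1cc(NC(=O)CN2CCC(c3cccc[n+]3[O-])CC2)ccc1F`: 18 nM. Compound 3 `COc1cccc(C)c1NC(=O)CN1CCC(c2cccc[n+]2[O-])CC1`: 340 nM.

In a functional assay on HEK293 cells for agonist activity at D(4) dopamine receptor (Homo sapiens), read by FLIPR (a lower number here means that less compound is needed, a higher number that more compound is needed for the effect), compound 2 stands at the lowest number of the three, with compound 1 and compound 3 both beyond the scatter above it. Compound 4 `CSc1cccc(NC(=O)CN2CCC(c3cccc[n+]3[O-])CC2)c1` has not been measured. It differs from compound 2 in one place: 3-(methylsulfanyl)phenyl in place of 4-fluoro-3-methylphenyl on an amide-type nitrogen. For the measured compounds named here, no two measured compounds differ in a single place, so no direct step of this kind is known. Compound 3 shows that an altered aryl group on the same nitrogen can move the number far upward, as its value 340 nM makes plain. A modest rise, perhaps within the scatter, is expected for compound 4. Compound 4 is estimated at 40 nM, between 12 nM and 130 nM, an expected step of a 2.2-fold higher number from compound 2 to compound 4 (0.35 log units; beyond the scatter).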

Compound 4, half-maximal effective concentration: 100 nM
Beside the measured number, compound 4's estimate is 2.5-fold (0.40 log units) below it; the range from low to high includes it.
By their numbers in this assay, from the lowest: compound 2; then compounds 1 and 4 (each within the scatter of the next); then compound 3.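

In this assay, the only single-place step shown gives a 5.6-fold higher number from compound 2 to compound 4 (0.74 log units; beyond the scatter), so at this amide-type nitrogen the aryl group can shift the number even when the heavy-atom count stays the same. 3-(Methylsulfanyl)phenyl has one hydrogen-bond acceptor by the count and 4-fluoro-3-methylphenyl none, but this one step cannot tie the shift to that difference. Nothing available explains the shift. As far as these compounds go, it remains open whether the fluorine or the methyl of compound 2 matters more. From the compounds shown here alone, how a methoxy group or a chlorine atom on the phenyl would compare also remains open.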